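The source may report more compounds than this note shows. Statements on the series, on what has been measured and on what is new or still open speak of the compounds shown alone.

Measured compounds in an ADME assay on microsomes from liver (Homo sapiens) for metabolic stability; a higher number here means that the compound lasts longer, a lower number that the compound disappears faster:
compound 1 `CC#C[C@@H](Cc1nnn[nH]1)c1ccc(OCc2ccc3scc(-c4ccccc4C(F)(F)F)c3c2)cc1`: in this assay compound 1 reports a limit, < 0.0667 h.
compound 2 `CC#C[C@@H](Cc1nnn[nH]1)c1ccc(OCc2ccc3sc(F)c(-c4ccccc4C)c3c2)cc1`: in this assay compound 2 gives 0.0667 h.
compound 3 `CC#C[C@@H](Cc1nnn[nH]1)c1ccc(OCc2ccc3sc(C)c(-c4ccccc4C)c3c2)cc1`: in this assay compound 3 gives 0.0667 h.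

Compound 1 stands at the limit of < 0.0667 h in this assay, at which 1 of the 3 values shown sits, so no number is known for it in this assay. Compound 4 `CC#C[C@@H](Cc1nnn[nH]1)c1ccc(OCc2ccc3scc(C4CC4)c3c2)cc1` differs from compound 1 in one place:
cyclopropyl in place of 2-(trifluoromethyl)phenyl on an aromatic carbon
For the measured compounds named here, the only measured step, no change at the digits printed from compound 2 to compound 3 (within the scatter), concerns another position of the shared core and does not bear on this replacement; no measured step covers cyclopropyl in place of 2-(trifluoromethyl)phenyl. With compound 1 at a limit and compounds 2 and 3 sharing one value, the series gives no ground for a large move, and a step within the scatter is expected: an at least 1.1-fold higher number from compound 1 to compound 4 (0.07 log units; that floor lies within the scatter) is the estimated step. Compound 4 is therefore estimated at 0.08 h, in the range 0.03 h to 0.25 h, with a real chance that this assay again reports only a limit.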

Compound 4, half-life: 0.267 h
For compound 4 the middle estimate is 3.3-fold (0.52 log units) below the measured one; the whole stated range lies below it.
By their numbers in this assay, from the lowest: compounds 2 and 3 (each within the scatter of the next); then compound 4.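

In this assay, the aromatic carbon two ring bonds from the ring sulfur proves sensitive to its substituent: cyclopropyl in place of 2-(trifluoromethyl)phenyl gives an at least 4.0-fold higher number from compound 1 to compound 4 (0.60 log units; beyond the scatter). This is the only change shown that reaches beyond the scatter. Its size is a floor and not a measured difference: the limit of < 0.0667 h in this assay, at which 1 of the 4 values shown sits.

This single pair does not separate the loss of the aromatic ring from the loss of the three fluorine atoms. From the compounds shown here alone, how an unsubstituted phenyl, an isopropyl group or an amine would behave on this carbon remains open.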